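Anilino analogue of compound 3: expected paw edema inhibition

The source may hold more compounds than are shown below. What is called first, only, known or untested is meant among the compounds shown, and "the series" means these compounds.

Of the compounds shown here, three of one series have been measured in a functional assay on the whole organism (strain Wistar) for inhibition, with Rattus norvegicus as the target, read by paw edema, with a stated time of 3 h, at a dose of 10 mg/kg by the oral route; a lower number here means less inhibition, a higher number more inhibition at the dose given (going by the name of the read-out). Compound 1 `Clc1ccccc1-c1nnc(COc2ccc(-c3ccccc3)cc2)o1` gives 59.1% and compound 2 `Cc1ccccc1-n1c(S)nnc1COc1ccc(-c2ccccc2)cc1` gives 56.8%; these two numbers lie within the usual scatter of each other, so no order between them is claimed. Compound 3 `CCCCNc1nnc(COc2ccc(-c3ccccc3)cc2)s1` stands lowest of the three with 27.3%: compound 2 sits above it by a margin beyond the scatter, and compound 1 further above, also beyond the scatter. Compound 3 is the only one of the three with a butyl chain on the amino nitrogen; compounds 1 and 2 each carry a substituted phenyl ring on the shared core.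

Compound 4 `Clc1ccc(Nc2nnc(COc3ccc(-c4ccccc4)cc3)s2)cc1` differs from compound 3 in one place: 4-chlorophenyl in place of butyl on a nitrogen on an aromatic ring. Within the data shown here, no step between two measured compounds covers this change, so its size can only be expected. The expectation rests on compound 1 giving 59.1% and compound 2 giving 56.8%, both aryl-bearing and both well above compound 3. An upward step is therefore expected, a number 18.7 percentage points higher from compound 3 to compound 4 (beyond the scatter), likely beyond the scatter though a smaller change cannot be excluded. The estimate for compound 4 in this assay is 46%, with a range from 30% to 62%.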

Compound 4, a percentage reported as inhibition, in the whole organism at one dose (the size of the read-out at that dose, not a potency): 52.3%
Estimate against measurement, compound 4: 6.3 percentage points below; the measured number falls inside the stated range.
By their numbers in this assay, from the lowest: compound 3; then compounds 4, 2 and 1 (each within the scatter of the next).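

In this assay, among these compounds, the change from butylamino to (4-chlorophenyl)amino gives a number 25 percentage points higher from compound 3 to compound 4 (beyond the scatter) and is the first step that can be read between two compounds differing in one place. It shows that the group on this nitrogen matters to the read-out at the dose given, since the rest of the structure stays the same in compound 3 and compound 4. Nothing at hand bears on why the number moves with this change.

The step replaces an open chain with a chlorine-bearing aromatic ring in one move, so the contribution of the ring cannot be separated from that of the chlorine; unsubstituted phenyl on the same nitrogen would divide the two, and cyclohexyl would set a ring without aromatic character against both butyl and 4-chlorophenyl. A single dose also leaves open whether the step reflects a shift in potency or only in the size of the effect at that dose, and a shorter chain such as methyl would show whether butyl itself sets the lower number.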